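Chain shortening toward compound 4

The source may report more compounds than this note shows. Statements on the series, on what has been measured and on what is new or still open speak of the compounds shown alone.

Compound 3 `CCCCCCCCCCOP(=O)(O)OCCSC(=S)N1CCCCC1` gives 62500 nM in a functional assay on PC-3 cells (Homo sapiens) for inhibition, read by MTT assay, with stated times of 18 h and 4 h; on this read-out higher numbers stand for weaker inhibition and lower numbers for stronger inhibition. Compound 1 `CCCCCCCCOP(=O)(O)OCCSC(=S)N1CCCCC1` reaches only the limit of this assay, > 100000 nM. The step of an at least 1.6-fold higher number from compound 3 to compound 1 (0.20 log units; that floor lies within the scatter) corresponds to the change (hydrogen in place of ethyl on a saturated chain carbon, eight bonds along the chain from an oxygen on an unsaturated carbon). That step is bounded by the limit of > 100000 nM in this assay, at which 1 of the 3 values shown sits. Compound 2 `CCCCCCCCOP(=O)(O)OCCSC(=S)N1CCCCCC1` gives 56800 nM in this assay, and the step of an at least 1.7-fold lower number from compound 1 to compound 2 (0.24 log units; that floor lies within the scatter) goes with azepan-1-yl in place of piperidin-1-yl on a thiocarbonyl carbon. How the cores of compound 2 and compound 3 differ is not broken down here. Compound 4 `CCCCCCOP(=O)(O)OCCSC(=S)N1CCCCCC1` is unmeasured; it arises from compound 2 by hydrogen in place of ethyl on a saturated chain carbon, six bonds along the chain from an oxygen on an unsaturated carbon, the same kind of change as that from compound 3 to compound 1, but placed six bonds along the chain from an oxygen on an unsaturated carbon rather than eight. A step of a 2.6-fold higher number from compound 2 to compound 4 (0.42 log units; beyond the scatter) is expected, resting on an at least 1.6-fold higher number from compound 3 to compound 1 (0.20 log units; that floor lies within the scatter). Compound 4 is estimated at 150000 nM, with the expected range running from 60000 nM to 400000 nM.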

Compound 4, half-maximal inhibitory concentration: > 100000 nM
Compound 4 ended at the assay's limit; the forecaster's own chance of this, stated with the estimate: 60%; the middle value is on the limit's open side.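

Compound 4 gives > 100000 nM in this assay, which is a limit of the assay and not a number. The step of an at least 1.7-fold higher number from compound 2 to compound 4 (0.24 log units; that floor lies within the scatter) is therefore only a floor. The change is not contradicted in passing from one core to the other, but its size on either core remains unknown, and equal size across the cores is not shown: the same change on two cores in this assay, an at least 1.6-fold higher number (0.20 log units; that floor lies within the scatter) from compound 3 to compound 1 and an at least 1.7-fold higher number (0.24 log units; that floor lies within the scatter) from compound 2 to compound 4; the limit leaves it open whether they differ

Open, from the compounds shown here alone, is whether a chain longer than that of compound 3 gives lower numbers on either core. Also open, going by these compounds, is whether a carboxylic acid or an amine at the far end of the chain changes the read-out in this assay.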